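This account rests on a few compounds, and the source may have more. Where it says the series, first, only, none or still open, it means among the compounds named here.

Measured compounds:
Compound 2, `O=c1ccc2cc(OCc3cc(-c4cccc(Cl)c4)no3)ccc2o1`, gives 32500 nM in a functional assay on COLO 205 cells (Homo sapiens) for cytotoxicity, read by MTT assay, with a stated time of 48 h; a lower number here means a stronger inhibitor, a higher number a weaker inhibitor.
Compound 1, `C#CCOc1ccc2oc(=O)ccc2c1`, gives "not determined" (no result reported) in this assay, that is, no reported result.

Among the measured compounds shown here, compound 2 is the only compound in this set with a number. For the measured compounds named here, compound 1 carries a different, smaller group on the shared core and was left without a result, so compound 2 stands alone: it can be ranked against nothing that was measured, and no step between measured compounds can be described. Its value is a weak one in absolute terms, with a half-maximal inhibitory concentration well up in the micromolar range.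

Compound 3, `O=c1ccc2cc(OCc3cc(-c4ccc([N+](=O)[O-])cc4)no3)ccc2o1`, differs from compound 2 in a single place: 4-nitrophenyl in place of 3-chlorophenyl on an aromatic carbon. Both keep the shared core and the five-membered ring that links it to the outer aromatic ring. Going by the values given here, with no measured step available to lean on, the expectation rests on compound 2 alone. The step is expected to stay within the usual scatter of repeated measurements, with no clear direction; the estimated step is a 1.1-fold lower number from compound 2 to compound 3 (0.03 log units; within the scatter). Compound 3 is therefore estimated at 30000 nM, with a plausible range from 10000 nM to 90000 nM.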

Compound 3, half-maximal inhibitory concentration: 47800 nM
Compound 3: middle estimate off by 1.6-fold (0.20 log units), on the low side; measured number inside the range.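

Among the compounds shown here, this is the first step that can be read in this assay: 4-nitrophenyl in place of 3-chlorophenyl, on the aromatic carbon next to the ring nitrogen of the five-membered ring, gives a 1.5-fold higher number from compound 2 to compound 3 (0.17 log units; within the scatter) and so no real difference. At this position, then, two quite different outer rings, one carrying a chlorine and the other a nitro group with its two hydrogen-bond acceptors, cannot be told apart in this cell test, and both compounds sit in the weak micromolar range. Nothing measured here bears on this result.

Because this swap alters both the group on the outer ring and its name-given position, the compounds shown cannot separate those two changes, and no step to compound 1 can be read. From the compounds shown here alone, it remains open whether an outer ring carrying an amine or a carboxylic acid, or a plain phenyl ring with no added group, would move the number beyond the usual scatter, or whether the flat result for compound 2 and compound 3 would hold.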